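The compounds below may be only part of what the source reports. "The series", "measured", "known", "first", "only" and "open" are said of these compounds alone.

Compounds 1 and 2 share one core and differ only in the group attached to a carbonyl carbon on a ring nitrogen. In a functional assay on isolated protein for inhibition of Glucose-dependent insulinotropic receptor (Homo sapiens), read by HTRF and cAMP accumulation (a lower number here means that less compound is needed, a higher number that more compound is needed for the effect), compound 1 `Cc1nc(S(C)(=O)=O)ccc1Oc1ncnc(OC2CCN(C(=O)OC(C)(C)C(F)(F)F)CC2)c1F` gives 6.53 nM. In this assay compound 2 `Cc1nc(S(C)(=O)=O)ccc1Oc1ncnc(OC2CCN(C(=O)SC3CCC3)CC2)c1F` gives 8.51 nM, nominally the higher of the two numbers, yet a 1.3-fold higher number from compound 1 to compound 2 (0.12 log units; within the scatter) means the pair cannot be told apart. Compound 3 `Cc1nc(S(C)(=O)=O)ccc1Oc1ncnc(OC2CCN(C(=O)C(C)(F)F)CC2)c1F` differs from compound 2 by 1,1-difluoroethyl in place of cyclobutylsulfanyl on a carbonyl carbon. Within the data shown here, the only step that bears on this exchange at the same carbonyl carbon stayed within the scatter, so for compound 3 a step of a 1.4-fold higher number from compound 2 to compound 3 (0.15 log units; within the scatter) is expected. Compound 3 is therefore estimated at 12 nM, within a range from 4 nM to 40 nM.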

Compound 3, half-maximal effective concentration: 37 nM
Estimate against measurement, compound 3: 3.1-fold (0.49 log units) below; the range from low to high includes it.
By their numbers in this assay, from the lowest: compounds 1 and 2 (each within the scatter of the next); then compound 3.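

This carbonyl carbon is not indifferent to its group, as the first exchange alone might have suggested: a 4.3-fold higher number from compound 2 to compound 3 (0.64 log units; beyond the scatter) and a 5.7-fold higher number from compound 1 to compound 3 (0.75 log units; beyond the scatter) are both modest but beyond the scatter. Both the cyclobutylsulfanyl group and the 1-methyl-1-(trifluoromethyl)ethoxy group give lower numbers than 1,1-difluoroethyl. Nothing measured here explains this difference.

Still open, from the compounds shown here alone, is where an amine or a longer chain on this carbonyl carbon would fall. The compounds shown also cannot separate the effect of the atom joined to the carbonyl carbon from that of the rest of the group.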